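The compounds below may be only part of what the source reports. "The series", "measured", "known", "first", "only" and "open" are said of these compounds alone.

Compound 1 `CN1CCN(CC(=O)NCC(=O)N(C)c2ccc(Cl)cc2C(=O)c2ccccc2Cl)CC1` was run in a functional assay on the whole organism with Mus musculus as the target, in the rotarod test; on this read-out higher numbers stand for an effect only at larger amounts of compound and lower numbers for an effect already at smaller amounts. In this assay compound 1 gives only a limit of the assay, > 100 mg/kg, and no number. Compound 3 `CN(C(=O)CNC(=O)c1ccccc1)c1ccc(Cl)cc1C(=O)c1ccccc1` likewise gives only a limit in this assay, > 100 mg/kg. Within the data shown here, compound 2 `NCC(=O)NCC(=O)Nc1ccc([N+](=O)[O-])cc1C(=O)c1ccccc1` is the single compound with a number in this assay, giving 24.8 mg/kg. Compound 1 therefore sits at the limit of > 100 mg/kg in this assay, at which 2 of the 3 values shown sit, and can be set against compound 2 in no finer way than that. Compound 4 `CC(=O)NCC(=O)N(C)c1ccc(Cl)cc1C(=O)c1ccccc1Cl` differs from compound 1 in one place: hydrogen in place of 4-methylpiperazin-1-yl on a saturated chain carbon bound to a carbonyl carbon. Among the measured compounds shown here, no step between two measured compounds is known in this assay, so this change has no measured counterpart to lean on. The step from compound 1 to compound 4 is expected to be a number no higher from compound 1 to compound 4 (the limit leaves the size open), that is, nothing beyond the scatter. For compound 4 the estimate in this assay is 100 mg/kg, within a range from 30 mg/kg to 300 mg/kg, with a fair chance that the assay once more reports only a limit.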

Compound 4, dose for half-maximal effect: 58 mg/kg
Compound 4: middle estimate off by 1.7-fold (0.24 log units), on the high side; the measured number falls inside the stated range.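

In this assay compound 4 gives a measured number, 58 mg/kg, so with hydrogen in place of 4-methylpiperazin-1-yl on this saturated chain carbon bound to a carbonyl carbon, the shared core still gives a readable effect. The change is an at least 1.7-fold lower number from compound 1 to compound 4 (0.23 log units; that floor lies within the scatter), and this is only a floor, so the real size of the step may be larger or may not exceed the usual scatter. Compound 1 gives no number, only a limit of the assay: the limit of > 100 mg/kg in this assay, at which 2 of the 4 values shown sit.

The compounds shown leave open whether a small amine such as dimethylamino, or a carboxylic acid, at this place would behave more like hydrogen or more like 4-methylpiperazin-1-yl. They also leave open where the true value of compound 1 lies, and with it the full size of this step.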